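From thiophen-2-yl to 2,5-dimethylthiophen-3-yl in compound 3

A few compounds are considered here, and "the series" means these few. Any claim that something is new, unique, unknown or untested is made for them only; others in the source may bear on it.

In a functional assay on cells (Cancer cell lines, Homo sapiens) for inhibition (on this read-out lower numbers stand for stronger inhibition of growth and higher numbers for weaker inhibition of growth), compound 3 (`N=C(N)N/N=C/c1c(-c2cccs2)nc2sccn12`) stands at 8320 nM and compound 2 (`N=C(N)N/N=C/c1c(-c2ccsc2)nc2sccn12`) at 14800 nM while compound 1 (`Cc1cc(-c2nc3sc(C)cn3c2/C=N/NC(=N)N)c(C)s1`) reads 14100 nM so compound 3 sits within the usual scatter of both and cannot be separated from either. The next case is compound 4 (`Cc1cc(-c2nc3sccn3c2/C=N/NC(=N)N)c(C)s1`). Here 2,5-dimethylthiophen-3-yl replaces thiophen-2-yl on an aromatic carbon of a five-membered aromatic ring with 2 nitrogen, part of a fused or bridged system of two rings (2,5-dimethylthiophen-3-yl in place of thiophen-2-yl on an aromatic carbon). For the measured compounds named here, the one measured step that touches this group is a change of thiophene alone (a 1.8-fold lower number from compound 2 to compound 3 (0.25 log units; within the scatter)) and it stays within the scatter. The closest guide is compound 1 (14100 nM) which carries the same 2,5-dimethylthiophen-3-yl group, along with a further methyl on the core that compound 4 lacks. No measurement isolates the effect of that methyl, so this comparison is only a rough one. Even so, no step beyond the scatter is expected in this assay and the estimated move (a 1.3-fold higher number from compound 3 to compound 4 (0.12 log units; within the scatter)) is small. Compound 4 is expected at 11000 nM (estimated range 5500 nM to 22000 nM).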

Compound 4, concentration for 50% growth inhibition: 17800 nM
For compound 4 the middle estimate is 1.6-fold (0.21 log units) below the measured one; the range from low to high includes it.
By their numbers in this assay, from the lowest: compounds 3, 1, 2 and 4 (each within the scatter of the next, the first and the last beyond it).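

In this assay, for the compounds shown here, this is the first step beyond the scatter: 2,5-dimethylthiophen-3-yl on this aromatic carbon gives a 2.1-fold higher number from compound 3 to compound 4 (0.33 log units; beyond the scatter) and so separates the group from thiophen-2-yl, though only modestly. Set against thiophen-3-yl, the same group gives a 1.2-fold higher number from compound 2 to compound 4 (0.08 log units; within the scatter) and stays within the scatter, so the separation appears only when thiophen-2-yl is the point of comparison, and the two unsubstituted thiophenes themselves cannot be told apart. The methyl on the core can now be read alone, and the change to hydrogen gives a 1.3-fold higher number from compound 1 to compound 4 (0.10 log units; within the scatter) within the scatter, so this assay does not distinguish hydrogen from methyl at that core carbon in the presence of 2,5-dimethylthiophen-3-yl.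

No available evidence explains any of these differences. The compounds shown leave open whether either thiophene methyl matters on its own, and whether a phenyl ring or an amine on this aromatic carbon would read differently from the thiophenes.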